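Dimethylphenyl in Place of Trifluoromethylphenyl on the Piperazine

This account rests on a few compounds, and the source may have more. Where it says the series, first, only, none or still open, it means among the compounds named here.

Three compounds have been measured:

compound 1, `CCCc1nc(-c2ccccc2)c(CNCCN2CCN(c3ccc(F)cc3)CC2)o1`: 54.1%
compound 2, `CCCc1nc(-c2ccccc2)c(CNCCCN2CCN(c3ccc(C(F)(F)F)cc3)CC2)o1`: 51.6%
compound 3, `CCCc1nc(-c2ccccc2)c(CNCCN2CCN(c3cccc(C)c3C)CC2)o1`: 66.7%

All three share the same core, and all were tested in an assay on HEK293 cells for inhibition of Voltage-dependent T-type calcium channel subunit alpha-1G (Homo sapiens), read by fluorescence, tested at 10 uM; a lower number here means less inhibition, a higher number more inhibition at the concentration tested (going by the name of the read-out). Compound 2 stands lowest of the three numbers. Its nearest neighbour is compound 1, whose value lies within the scatter of that of compound 2, so no order can be read between them. Compound 3 lies furthest away, beyond the scatter.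

Among the measured compounds shown here, the one measured step that changes the aryl group on the ring nitrogen is a number 12.6 percentage points higher from compound 1 to compound 3 (beyond the scatter), a modest gain.

Compound 4, `CCCc1nc(-c2ccccc2)c(CNCCCN2CCN(c3ccc(C)c(C)c3)CC2)o1`, has not been measured. It differs from compound 2 in one place: 3,4-dimethylphenyl in place of 4-(trifluoromethyl)phenyl on an amine nitrogen in a ring. For the measured compounds named here, this is the same kind of exchange as the step from compound 1 to compound 3, a fluorinated phenyl giving way to a dimethylphenyl, though here with a different substitution pattern and a longer linker, for which no step is on record. On the strength of that single modest gain, compound 4 is expected to show a step of a number 9.4 percentage points higher from compound 2 to compound 4 (within the scatter), and its inhibition in this assay is estimated at 61%, within a range of 48% to 74%.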

Compound 4, a percentage reported as inhibition, at one concentration (the size of the read-out at that concentration, not a potency): 54.6%
Estimate against measurement, compound 4: 6.4 percentage points above; the measured number falls inside the stated range.
By their numbers in this assay, from the lowest: compounds 2, 1 and 4 (each within the scatter of the next); then compound 3.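

In this assay, the exchange on an amine nitrogen in a ring gives a number 3 percentage points higher from compound 2 to compound 4 (within the scatter), so 3,4-dimethylphenyl and 4-(trifluoromethyl)phenyl cannot be told apart at this position in compound 2 and compound 4. The earlier step, a number 12.6 percentage points higher from compound 1 to compound 3 (beyond the scatter), therefore does not extend to every exchange of a fluorinated phenyl for a dimethylphenyl: one pair shows a difference beyond the scatter and the other does not, and the two pairs differ both in the placing of the methyl groups and in the chain that joins the piperazine to the shared core. No evidence is available that bears on why the two steps differ.

The compounds shown leave open whether the dimethyl pattern or the chain separates the two results, since 2,3-dimethylphenyl appears only with the chain of compound 3 and 3,4-dimethylphenyl only with the chain of compound 4. They also leave open how a phenyl carrying a methoxy group or a chlorine atom would read at this position.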